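A few compounds are considered here, and "the series" means these few. Any claim that something is new, unique, unknown or untested is made for them only; others in the source may bear on it.

Measured compounds in an ADME assay on BJ cells (Homo sapiens) for cytotoxicity, with a stated time of 72 h; on this read-out higher numbers stand for an effect only at larger amounts of compound and lower numbers for an effect already at smaller amounts:
- compound 1 `Cc1nn(-c2ccccc2)c2nc(-c3ccccc3)c(C#N)c(-c3ccccc3O)c12`: > 23000 nM (a limit)
- compound 2 `Cc1ccccc1-c1nc2c(c(C)nn2-c2ccccc2)c(-c2ccccc2O)c1C#N`: 21000 nM
- compound 3 `Cc1nn(-c2ccccc2)c2nc(-c3ccc4ccccc4c3)c(C#N)c(-c3ccccc3O)c12`: > 20000 nM (a limit)

Compound 3 has no number, only the limit > 20000 nM. Compound 1 likewise has only a limit, > 23000 nM. Going by the values given here, compound 2 is the one compound with a number, 21000 nM.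

The next compound is compound 4 `Cc1nn(-c2ccccc2)c2nc(-c3ccc(S(C)(=O)=O)cc3)c(C#N)c(-c3ccccc3O)c12`, where 4-(methylsulfonyl)phenyl stands in place of naphthalen-2-yl, on the aromatic carbon next to the ring nitrogen and ortho to the cyano group: 4-(methylsulfonyl)phenyl in place of naphthalen-2-yl on an aromatic carbon.

All three measured steps alter the same substituent. The only one with a readable floor is an at least 1.0-fold lower number from compound 1 to compound 2 (0.03 log units; that floor lies within the scatter). The two steps that involve naphthalen-2-yl give no size: a step that the two limits leave unreadable from compound 1 to compound 3, and a step that the limit leaves unreadable from compound 2 to compound 3. Among the compounds with values here, no measured step therefore shows this substituent moving the read-out beyond the scatter, though the limits leave much unseen, and none of the three compounds carries 4-(methylsulfonyl)phenyl. No step beyond the scatter is expected in this assay, and a limit is the likelier report.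

The expected change is a step that the limit leaves unreadable from compound 3 to compound 4. Compound 4 is estimated at 23000 nM, with an expected range of 11000 nM to 45000 nM.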

Compound 4, half-maximal effective concentration: > 20000 nM
Compound 4 was reported as a limit; the forecaster's own chance of this, stated with the estimate: 70%; the middle value is on the limit's open side.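

None of the steps from compound 1, compound 2 and compound 3 to compound 4 can be read in this assay. Compound 4 gives only a limit, > 20000 nM. The compounds shown leave open where the values of compound 1, compound 3 and compound 4 actually lie, and whether any substituent at this place on the shared core moves the read-out beyond the usual scatter.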